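The Same Change Carried onto a Core Without a Number

The source may hold more compounds than are shown below. What is called first, only, known or untested is meant among the compounds shown, and "the series" means these compounds.

Compound 1 `COc1ccc(Oc2ccc(C(C)C)cc2-c2ccsc2S(=O)(=O)NCCNC(=S)Nc2ccc([N+](=O)[O-])cc2)cc1OC` and compound 2 `CC(C)c1ccc(Oc2ccc(O)c(O)c2)c(-c2ccsc2S(=O)(=O)NCCNC(=S)Nc2ccc([N+](=O)[O-])cc2)c1` share one core and differ in a single place: 3,4-dihydroxyphenyl in place of 3,4-dimethoxyphenyl on an oxygen on an aromatic ring. In a functional assay on HL-60 cells (Homo sapiens) for inhibition, read by CCK-8 assay, with a stated time of 48 h (on this read-out lower numbers stand for stronger inhibition and higher numbers for weaker inhibition), compound 1 gives 11200 nM, and compound 2 gives 8800 nM. That is a 1.3-fold lower number from compound 1 to compound 2 (0.10 log units; within the scatter), so the change left the read-out essentially where it stood.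

Compound 3 `COc1ccc(Oc2ccccc2-c2ccsc2S(=O)(=O)N2CCN(C(=O)Nc3ccc([N+](=O)[O-])cc3)CC2)cc1OC` has a different core; how the core of compound 3 differs from the core of compound 1 is not broken down here. In this assay compound 3 gives only a limit, > 50000 nM, and not a number. That is the limit of > 50000 nM in this assay, at which 1 of the 3 values shown sits.

Compound 4 `O=C(Nc1ccc([N+](=O)[O-])cc1)N1CCN(S(=O)(=O)c2sccc2-c2ccccc2Oc2ccc(O)c(O)c2)CC1` is what compound 3 becomes by the same change: 3,4-dihydroxyphenyl in place of 3,4-dimethoxyphenyl on an oxygen on an aromatic ring. The place where the change sits reads the same in both pairs, so it is the same change. The expected step for compound 4 is a step that the limit leaves unreadable from compound 3 to compound 4, which rests on a 1.3-fold lower number from compound 1 to compound 2 (0.10 log units; within the scatter) and on the limit shown for compound 3. Compound 4 is therefore estimated to give about 60000 nM in this assay, most likely again as a limit, somewhere between 25000 nM and 150000 nM.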

Compound 4, half-maximal inhibitory concentration: 4900 nM
For compound 4 the middle estimate is 12-fold (1.09 log units) above the measured one; the whole stated range lies above it.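

In this assay, putting 3,4-dihydroxyphenyl in place of 3,4-dimethoxyphenyl gives an at least 10-fold lower number from compound 3 to compound 4 (1.00 log units; beyond the scatter), so on this core the change does shift the read-out, and the two cores do not respond alike: the same change on two cores in this assay, a 1.3-fold lower number (0.10 log units; within the scatter) from compound 1 to compound 2 and an at least 10-fold lower number (1.00 log units; beyond the scatter) from compound 3 to compound 4, at least 8.0-fold (0.90 log units) apart, beyond the scatter of two such steps. Compound 3 stands at a limit and not a number, so this step has a floor but no exact size: the limit of > 50000 nM in this assay, at which 1 of the 4 values shown sits. The result on the core of compound 1 therefore did not carry over to the core of compound 3, but with one pair on each core this shows no rule for the series and does not tell which difference between the cores matters.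

The compounds shown leave open which part of the core separates the two results. They also leave open what would happen on either core with an amine or a carboxylic acid in place of the two hydroxyl groups, or with a single hydroxyl group on that ring.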